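A few compounds are considered here, and "the series" means these few. Any claim that something is new, unique, unknown or untested is made for them only; others in the source may bear on it.

Working notes on the series.

Of the compounds shown here, three have been measured in an assay for binding affinity to Apoptosis regulator Bcl-2 (Homo sapiens), read by fluorescence polarization, with a stated time of 2 h; a higher number here means a weaker inhibitor, a lower number a stronger inhibitor. Compound 1 `CCCn1c(C)c(C(=O)O)c(-c2cccc(N3CCN(c4ccc(NS(=O)(=O)c5ccc(N[C@H](CCN6CCC(O)CC6)CSc6ccccc6)c(S(=O)(=O)C(F)(F)F)c5)cc4)CC3)c2)c1-c1ccc(Cl)cc1` gives 7.5 nM in this assay, and compound 2 `Cc1c(C(=O)O)c(-c2cccc(N3CCN(c4ccc(NS(=O)(=O)c5ccc(N[C@H](CCN6CC(O)C6)CSc6ccccc6)c(S(=O)(=O)C(F)(F)F)c5)cc4)CC3)c2)c(-c2ccc(Cl)cc2)n1C` gives 1.7 nM. Compound 3 `Cc1c(C(=O)NCCCN2CCN(C)CC2)c(-c2cccc(N3CCN(c4ccc(NS(=O)(=O)c5cccc(S(=O)(=O)C6CC6)c5)cc4)CC3)c2)c(-c2ccc(Cl)cc2)n1C` gives 218 nM in this assay and so stands with the highest number of the three; its nearest neighbour on the numbers is compound 1 and its furthest is compound 2, both gaps beyond the scatter. No pair of these compounds differs in only one place, so none of the gaps can be read as a single step.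

Compound 4 `Cc1c(C(=O)NCCCN2CCN(C)CC2)c(-c2cccc(N3CCN(c4ccc(NS(=O)(=O)c5cccc(OC(C)C)c5)cc4)CC3)c2)c(-c2ccc(Cl)cc2)n1C` has not been measured. It differs from compound 3 in one place: isopropoxy in place of cyclopropylsulfonyl on an aromatic carbon. The group that enters is smaller and has one hydrogen-bond acceptor fewer than the group that leaves, and it keeps no ring. Within the data shown here, nothing among the measured compounds tests this kind of exchange, so the size and direction of the step rest on general expectation only.

The step from compound 3 to compound 4 is expected to be small, a 1.4-fold higher number from compound 3 to compound 4 (0.14 log units; within the scatter), within or only slightly beyond the scatter, and leaning toward a higher number. Compound 4 is therefore estimated at 300 nM in this assay, with a range from 80 nM to 1200 nM.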

Compound 4, inhibition constant: 522 nM
Compound 4: the middle estimate sits 1.7-fold (0.24 log units) below what was measured, within the range that was stated.
By their numbers in this assay, from the lowest: compound 2; then compound 1; then compound 3; then compound 4.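

Among these compounds, this is the first step that can be read as a single change: in this assay, isopropoxy in place of cyclopropylsulfonyl on an aromatic carbon, meta to a large group, gives a 2.4-fold higher number from compound 3 to compound 4 (0.38 log units; beyond the scatter). The number at this position therefore responds to the group it carries, modestly but beyond the scatter, and of this one pair the cyclopropylsulfonyl compound, compound 3, has the lower number. No measurement bears on which feature of the exchange accounts for the step.

The exchange alters the sulfonyl, the ring and the heavy-atom count at once, so the compounds shown cannot assign the step to any one of them; isopropylsulfonyl or cyclopropoxy on the same carbon would separate these features, and a smaller group such as methoxy or an amine would show how far the position extends in either direction. Also open, as far as these compounds go, is whether the same exchange gives a step of similar size and direction on a compound with the carboxylic acid of compound 2 in place of the side-chain amide of compound 3.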